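Chalcones on the shared core: nitro to chloro on the aryl

A few compounds are considered here, and "the series" means these few. Any claim that something is new, unique, unknown or untested is made for them only; others in the source may bear on it.

Compound 1 `COc1ccc(C(=O)/C=C/c2ccc(N3CCCC3)cc2)c2c1C=CC(C)(C)O2` gives 8590 nM in a functional assay on HCT-116 cells (Homo sapiens) for antiproliferative activity, read by MTT assay, with a stated time of 24 h; on this read-out higher numbers stand for weaker inhibition and lower numbers for stronger inhibition. Compound 2 `COc1ccc(C(=O)/C=C/c2ccc([N+](=O)[O-])cc2)c2c1C=CC(C)(C)O2` gives 8880 nM in this assay. Compound 3 `COc1ccc(C(=O)/C=C/c2ccc(C(F)(F)F)cc2)c2c1C=CC(C)(C)O2` returns only the limit > 10000 nM in this assay.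

Compound 2 holds the higher of the two numbers that are real readings, with compound 1 close by, and the third reading is a limit rather than a number. The measured steps around compound 2 are flat: a 1.0-fold higher number from compound 1 to compound 2 (0.01 log units; within the scatter) and an at least 1.1-fold higher number from compound 2 to compound 3 (0.05 log units; that floor lies within the scatter), with the step to compound 3 only a floor since its reading sits at the limit of > 10000 nM in this assay, at which 1 of the 3 values shown sits. Compound 3 itself moves no further from compound 1 than an at least 1.1-fold higher number from compound 1 to compound 3 (0.06 log units; that floor lies within the scatter).

Compound 4 `COc1ccc(C(=O)/C=C/c2cccc(Cl)c2)c2c1C=CC(C)(C)O2` differs from compound 2 by 3-chlorophenyl in place of 4-nitrophenyl on a double-bonded chain carbon bound to a double-bonded chain carbon. Across the aryl changes seen so far the numbers barely move, so no step beyond the scatter is expected here either, in neither direction. The step of a 1.0-fold higher number from compound 2 to compound 4 (0.01 log units; within the scatter) is therefore expected to stay within the scatter. Compound 4 is estimated at 9000 nM, with a range from 4500 nM to 18000 nM, and a real chance that only a limit is reported.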

Compound 4, half-maximal inhibitory concentration: > 10000 nM
Compound 4 ended at the assay's limit (the forecaster's own chance of this, stated with the estimate: 40%); middle value at least 1.1-fold (0.04 log units) away from the limit.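

Swapping 4-nitrophenyl for 3-chlorophenyl on a double-bonded chain carbon bound to a double-bonded chain carbon gives an at least 1.1-fold higher number from compound 2 to compound 4 (0.05 log units; that floor lies within the scatter), so this change, which replaces the nitro group with chlorine and alters the name's ring number, shows no step beyond the scatter. Compound 4 gives > 10000 nM in this assay, and that value is a limit of the assay, not a number. The aryl changes shown now reach that limit with a second group, 3-chlorophenyl, and no value from this change falls outside the scatter of compound 2: the limit of > 10000 nM in this assay, at which 2 of the 4 values shown sit.

As far as these compounds go, how far compound 4 lies past the limit stays unknown, so the true size of its step cannot be read. The compounds shown also leave open how a hydroxyl, a primary amine or a carboxylic acid on the aryl ring would read.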